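Removing the para-fluoro from the thiourea phenyl ring

The source may hold more compounds than are shown below. What is called first, only, known or untested is meant among the compounds shown, and "the series" means these compounds.

Compound 1 `Fc1ccc(NC(=S)Nc2nc3ccccc3s2)cc1` is one of three thioureas examined in a functional assay on THP-1 cells (Homo sapiens) for cytotoxicity, read by MTT assay, with a stated time of 48 h; on this read-out lower numbers stand for stronger inhibition and higher numbers for weaker inhibition; compound 1 gives 26700 nM. Its near relatives are compound 2 `Fc1ccc(NC(=S)Nc2nc3ccc(F)cc3s2)cc1`, for which this assay gives 34600 nM, and compound 3 `Fc1ccc2nc(Nc3nc4c(Cl)cccc4s3)sc2c1`, which gives 36200 nM. Compound 1 has the lowest number of the three, but the spread among them stays within the usual scatter, so no order can be claimed. Among the compounds with values here, the one single-point step among them, a 1.3-fold higher number from compound 1 to compound 2 (0.11 log units; within the scatter), is within the scatter as well.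

Compound 4 `S=C(Nc1ccccc1)Nc1nc2ccccc2s1` differs from compound 1 by hydrogen in place of fluoro on an aromatic carbon, on an aromatic carbon of a six-membered aromatic ring of carbon only, para to a large group. Within the data shown here, no measured step concerns that ring directly; the only step at hand, a 1.3-fold higher number from compound 1 to compound 2 (0.11 log units; within the scatter), shows that adding a fluoro elsewhere on the shared core leaves the read-out in this assay essentially unchanged. On that basis the expectation for compound 4 is a step of a 1.0-fold higher number from compound 1 to compound 4 (0.00 log units; within the scatter), that is, none beyond the scatter. Compound 4 is therefore estimated at 27000 nM in this assay, with a range from 12000 nM to 60000 nM.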

Compound 4, half-maximal inhibitory concentration: 36500 nM
Beside the measured number, compound 4's estimate is 1.4-fold (0.13 log units) below it, and the stated range covers the measured number.
By their numbers in this assay, from the lowest: compounds 1, 2, 3 and 4 (each within the scatter of the next).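

In this assay, within the data shown here, the step of a 1.4-fold higher number from compound 1 to compound 4 (0.14 log units; within the scatter) lies within the scatter, and it is the first measured change on this aromatic carbon of a six-membered aromatic ring of carbon only, para to a large group. The earlier step concerned a fluoro elsewhere on the shared core, whereas this one shows that the read-out does not separate fluoro from hydrogen at this place. No measurement at hand bears on what lies behind this result.

From the compounds shown here alone, whether a larger or differently built group at this place, such as a methoxy, an amine or a carboxylic acid, would shift the number beyond the scatter stays open. With fluoro and hydrogen as the only two groups shown here, the compounds also leave open whether this place can affect the read-out at all.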